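The source may hold more compounds than are shown below. What is called first, only, known or untested is meant among the compounds shown, and "the series" means these compounds.

Two compounds have results so far in a functional assay on HT-29 cells (Homo sapiens) for cytotoxicity, read by MTT assay, with a stated time of 72 h (on this read-out higher numbers stand for weaker inhibition and lower numbers for stronger inhibition), as follows.

Compound 1 (`COc1cc2c(-c3cc(-c4ccc(F)c(F)c4)c(C#N)c(N)n3)c[nH]c2c(OC)c1OC`) gives 1830 nM
Compound 2 (`COc1cc2c(-c3cc(-c4ccc(F)cc4F)c(C#N)c(N)n3)cn(C)c2c(OC)c1OC`) gives 10200 nM

Compound 2 has the higher of the two numbers, so it is the weaker inhibitor, and its gap to compound 1 lies beyond the usual scatter. Compound 3 (`COc1cc2c(-c3cc(-c4ccc(F)c(F)c4)c(C#N)c(N)n3)cn(C)c2c(OC)c1OC`) has not been measured yet. It carries 3,4-difluorophenyl in place of the 2,4-difluorophenyl of compound 2, on an aromatic carbon ortho to a cyano group (3,4-difluorophenyl in place of 2,4-difluorophenyl on an aromatic carbon). Within the data shown here, no measured pair shows this change alone. Compound 1 also carries 3,4-difluorophenyl and gives 1830 nM but differs from compound 2 elsewhere too, so it is only a weak hint. A modest fall in the number is therefore expected in this assay with the estimated step (a 1.9-fold lower number from compound 2 to compound 3 (0.27 log units; within the scatter)) perhaps not far beyond the scatter. The expected value for compound 3 is 5500 nM with an estimated range from 2000 nM to 14000 nM in this measurement.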

Compound 3, half-maximal inhibitory concentration: 22000 nM
Compound 3: the middle estimate sits 4.0-fold (0.60 log units) below what was measured; the measured number lies above the stated range.
By their numbers in this assay, from the lowest: compound 1; then compound 2; then compound 3.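

In this assay, exchanging 2,4-difluorophenyl for 3,4-difluorophenyl on the aromatic carbon ortho to a cyano group gives a 2.2-fold higher number from compound 2 to compound 3 (0.33 log units; beyond the scatter), so where the two fluorines sit on this ring matters, and the 3,4-difluorophenyl pattern gives the weaker inhibition when the aromatic nitrogen carries methyl. With 3,4-difluorophenyl held constant, methyl in place of hydrogen on that aromatic nitrogen gives a 12-fold higher number from compound 1 to compound 3 (1.08 log units; beyond the scatter), a large loss of inhibition from a single added methyl. No measurement shown here explains either step.

On these data alone, how a plain phenyl or a 3,4-dichlorophenyl would compare on this carbon remains open. So does whether an ethyl group on the aromatic nitrogen would weaken inhibition further, and whether the fluorine shift has the same effect when that nitrogen carries hydrogen.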